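Side-chain diol variant of the hydroxyalkyl series

This account rests on a few compounds, and the source may have more. Where it says the series, first, only, none or still open, it means among the compounds named here.

The three measured compounds share one core and differ only in the short hydroxylated chain on the aromatic nitrogen. In a functional assay on CCRF-CEM cells (Homo sapiens) for antiproliferative activity, read by MTT assay, with a stated time of 48 h, tested at 50 uM (on this read-out higher numbers stand for a weaker effect at the one concentration tested and lower numbers for a stronger effect), compound 1 `C[C@@H](O)CCn1nc2c(Br)c(Br)c(Br)c(Br)c2n1` gives 23%. Its mirror-drawn partner compound 2 `C[C@H](O)CCn1nc2c(Br)c(Br)c(Br)c(Br)c2n1` gives 42%. Compound 3 `CC(O)CCn1nc2c(Br)c(Br)c(Br)c(Br)c2n1`, drawn without a configuration at the chain carbon, gives 45%, the highest of the three numbers. The step of a number 19 percentage points higher from compound 1 to compound 2 (beyond the scatter) rests on (the fact that compounds 1 and 2 differ only in the configuration as drawn), and the step of a number 22 percentage points higher from compound 1 to compound 3 (beyond the scatter) on (the fact that one of compounds 1 and 3 is drawn with a defined configuration and the other without, at the place where they differ). The step of a number 3 percentage points higher from compound 2 to compound 3 (within the scatter) lies within the scatter, so compound 2 and compound 3 are not separated on this read-out, consistent with the fact that one of compounds 2 and 3 is drawn with a defined configuration and the other without, at the place where they differ.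

Compound 4 `OCC(O)Cn1nc2c(Br)c(Br)c(Br)c(Br)c2n1` differs from compound 3 by 1,2-dihydroxyethyl in place of 2-hydroxypropyl on a saturated chain carbon bound to an aromatic nitrogen. Within the data shown here, none of the measured steps alters the chain itself; each only changes how a single stereocentre is drawn, so none bears directly on this change, and the measured steps give no direction for it. The three measured values span only a modest width at the one concentration. Compound 4 is therefore expected to stay close to compound 3, with the step of a number 3 percentage points higher from compound 3 to compound 4 (within the scatter) estimated as no more than the scatter. The estimated value for compound 4 is 48%, within a range of 25% to 78%.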

Compound 4, a percentage reported as activity, at one concentration (the size of the read-out at that concentration, not a potency): 27%
Estimate against measurement, compound 4: 21 percentage points above; low and high end bracket the measured number.
By their numbers in this assay, from the lowest: compounds 1 and 4 (each within the scatter of the next); then compounds 2 and 3 (each within the scatter of the next).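

In this assay, among these compounds, the change from 2-hydroxypropyl to 1,2-dihydroxyethyl on a saturated chain carbon bound to an aromatic nitrogen is the first measured change to the chain itself, and this position responds to it (two steps: a number 18 percentage points lower from compound 3 to compound 4 (beyond the scatter) and a number 15 percentage points lower from compound 2 to compound 4 (beyond the scatter)). Configuration as drawn is therefore not the only feature of this chain that moves the read-out, and compound 4, drawn without a defined configuration, is not separated from the R-drawn compound 1 on this read-out (a number 4 percentage points higher from compound 1 to compound 4 (within the scatter)). The facts at hand concern only how a single stereocentre is drawn, and none of them accounts for this chain change.

Whether configuration at the chain carbon of compound 4 matters as it does for compound 1 and compound 2 remains open, since the single forms of this diol are not among the compounds shown. Also open, on these data alone, is how an amine, a carboxylic acid or a longer chain in place of 1,2-dihydroxyethyl would read on the shared core.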